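Replacing an Ether Side Chain with a Cyclic Ester

The compounds below may be only part of what the source reports. "The series", "measured", "known", "first", "only" and "open" are said of these compounds alone.

Measured compounds:
compound 1, `CC(=O)OCCO[C@H](CC=C(C)C)C1=CC(=O)c2c(O)ccc(O)c2C1=O`: in a functional assay on DU-145 cells (Homo sapiens) for cytotoxicity, read by MTT assay (on this read-out higher numbers stand for weaker inhibition and lower numbers for stronger inhibition), compound 1 gives 15500 nM
compound 2, `CC(=O)OC(C)CO[C@H](CC=C(C)C)C1=CC(=O)c2c(O)ccc(O)c2C1=O`: in this assay compound 2 gives 16600 nM

For the measured compounds named here, compound 2 gives the higher of the two numbers, but its only neighbour is compound 1 and the gap between them is within the scatter, so no order between the two can be claimed. Going by the values given here, the single measured step, a 1.1-fold higher number from compound 1 to compound 2 (0.03 log units; within the scatter), is the only guide the data offer, and it concerns a different part of the molecule from the change studied here.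

Compound 3, `CC(C)=CC[C@@H](OC(=O)C1CCCOC1)C1=CC(=O)c2c(O)ccc(O)c2C1=O`, differs from compound 2 by (oxan-3-yl)carbonyl in place of 2-acetoxypropyl on an oxygen on a saturated carbon. Among the compounds with values here, no measured step covers a change of this kind: the one step available was within the scatter and touched only the 2-acetoxypropyl group, not the oxygen bearing it. The expectation for compound 3 therefore rests on the value of compound 2 alone, with a wide range to reflect the absence of guidance. Compound 3 is expected to give 16000 nM, with a range from 5000 nM to 50000 nM. The expected step is a 1.0-fold lower number from compound 2 to compound 3 (0.02 log units; within the scatter), that is, none beyond the scatter.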

Compound 3, half-maximal inhibitory concentration: 29700 nM
Estimate against measurement, compound 3: 1.9-fold (0.27 log units) below; measured number inside the range.
By their numbers in this assay, from the lowest: compounds 1, 2 and 3 (each within the scatter of the next).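

For the compounds shown here, compound 3 is the first compound here in which the oxygen on the saturated carbon carries (oxan-3-yl)carbonyl, and in this assay the exchange for 2-acetoxypropyl reads as a 1.8-fold higher number from compound 2 to compound 3 (0.25 log units; within the scatter) and the exchange for 2-acetoxyethyl reads as a 1.9-fold higher number from compound 1 to compound 3 (0.28 log units; within the scatter) in the same assay. The earlier step touched only a methyl on the side chain, whereas these steps replace the whole group on this oxygen and bring in a six-membered non-aromatic ring where compounds 1 and 2 have none, yet both steps stay within the scatter and no order among the three compounds can be claimed. No measurement at hand bears on what lies behind these numbers.

The carbonyl and the ring enter together in compound 3, so the compounds shown cannot tell the part played by each one, as a plain acetyl group on this oxygen might. They also leave open whether an amine or a carboxylic acid on the oxygen's side chain, or a longer chain there, would give a number beyond the scatter of these three.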